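Phenylethenyl replacing chlorophenyl: cytotoxicity outlook

The compounds below may be only part of what the source reports. "The series", "measured", "known", "first", "only" and "open" are said of these compounds alone.

Compound 1 `O=C(c1ccncc1)N1N=C(c2cc3ccccc3o2)CC1c1ccc(Cl)cc1` and compound 2 `O=C(c1ccncc1)N1N=C(c2cc3ccccc3o2)CC1c1ccccc1Cl` share one core. In an ADME assay on Vero cells (Chlorocebus sabaeus) for cytotoxicity, read by MTT assay, with a stated time of 72 h (on this read-out lower numbers stand for stronger inhibition and higher numbers for weaker inhibition), compound 1 gives only the limit > 220000 nM. In this assay compound 2 gives only the limit > 210000 nM. The step that the two limits leave unreadable from compound 1 to compound 2 is thus not readable, as the limit of > 210000 nM in this assay, at which 1 of the 2 values shown sits, and the limit of > 220000 nM in this assay, at which 1 of the 2 values shown sits, show. Compound 3 `O=C(c1ccncc1)N1N=C(c2cc3ccccc3o2)CC1/C=C/c1ccccc1` carries 2-phenylethenyl in place of 2-chlorophenyl on a saturated ring carbon. Among the measured compounds shown here, no measured step bears readably on this change, since both known values are limits. Compound 3 is expected to stay at a limit, with the step that the limit leaves unreadable from compound 2 to compound 3 estimated within the scatter. The estimate for compound 3 is 220000 nM, ranging from 60000 nM to 400000 nM.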

Compound 3, half-maximal inhibitory concentration: > 212000 nM
Compound 3 ended at the assay's limit (the forecaster's own chance of this, stated with the estimate: 80%); the middle value lies beyond the limit too.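

In this assay compound 3 gives only the limit > 212000 nM. Among the compounds shown here, with compound 1 and compound 2 also at limits, no step among the three can be read. As far as these compounds go, their actual cytotoxicity concentrations remain open.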